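From Chloro to Nitro in a Growth Inhibition Series

This account rests on a few compounds, and the source may have more. Where it says the series, first, only, none or still open, it means among the compounds named here.

Values measured in a functional assay on DU-145 cells (Homo sapiens) for inhibition, read by trypan blue exclusion, with a stated time of 96 h; a higher number here means a weaker inhibitor of growth, a lower number a stronger inhibitor of growth:
- Compound 1 `CN(C)c1ccc(/C=C(/SCc2ccc(Cl)cc2)C(=O)c2ccc(C(=O)O)cc2)cc1`: 1000 nM.
- Compound 2 `Cc1ccc(/C=C(/SCc2ccc(Cl)cc2)C(=O)c2ccc([N+](=O)[O-])cc2)s1`: 25000 nM.
- Compound 3 `CN(C)c1ccc(/C=C(/SCc2ccc(Cl)cc2)C(=O)c2ccc(Cl)cc2)cc1`: > 100000 nM, a limit and not a number.

Compound 3 stands at the top of the scale, and its > 100000 nM is only a limit of the assay.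

Compound 4 `CN(C)c1ccc(/C=C(/SCc2ccc(Cl)cc2)C(=O)c2ccc([N+](=O)[O-])cc2)cc1` differs from compound 3 in one group: nitro in place of chloro on an aromatic carbon. In words, this is nitro in place of chloro on an aromatic carbon, turning 4-chlorophenyl into 4-nitrophenyl.

One measured step involves a change on this aromatic carbon: an at least 100-fold higher number from compound 1 to compound 3 (2.00 log units; beyond the scatter). That large step, beyond the scatter, shows that the group here can matter greatly in this assay, but it had carboxy, not nitro, as its partner. Compound 2 also carries 4-nitrophenyl, though it differs elsewhere, and compound 2 gives a true number, 25000 nM. On that slim evidence, a step beyond the scatter towards a lower number is expected, with much uncertainty.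

The expected change is an at least 6.6-fold lower number from compound 3 to compound 4 (0.82 log units; beyond the scatter).

The estimated value for compound 4 is 15000 nM, with an expected range of 3000 nM to 80000 nM.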

Compound 4, concentration for 50% growth inhibition: > 100000 nM
Compound 4 ended at the assay's limit (the forecaster's own chance of this, stated with the estimate: 25%); middle value at least 6.6-fold (0.82 log units) away from the limit.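

In this assay compound 4 gives > 100000 nM, which is a limit and not a number, and the change from chloro to nitro cannot be read, because compound 3 stands at the same limit: the limit of > 100000 nM in this assay, at which 2 of the 4 values shown sit.

What is new is that nitro, like chloro, fails to keep the value that carboxy gives on this aromatic carbon of the shared core: nitro in place of carboxy gives an at least 100-fold higher number from compound 1 to compound 4 (2.00 log units; beyond the scatter). The 4-nitrophenyl group also does not give a readable value by itself, as 4-(dimethylamino)phenyl in place of 5-methylthiophen-2-yl gives an at least 4.0-fold higher number from compound 2 to compound 4 (0.60 log units; beyond the scatter), so the group at the other end of the molecule matters as well.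

As far as these compounds go, how far compound 3 and compound 4 lie beyond the limit stays unknown, so neither chloro nor nitro can be ranked against the other. From the compounds shown here alone, it also remains open whether a readable value with 4-(dimethylamino)phenyl needs the carboxylic acid itself, or whether an amide or a hydroxyl group on this carbon would also give one.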